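Swapping a Chlorophenyl for a Fluorophenyl on the Shared Core

The compounds below may be only part of what the source reports. "The series", "measured", "known", "first", "only" and "open" are said of these compounds alone.

Compound 1 `N#Cc1ccc(-c2ccc(C(=O)Nc3ccc4cccnc4c3)cn2)cc1`: in an in vitro functional assay on 1321-N1 cells for antagonist activity at transient receptor potential cation channel subfamily V member 1 (Homo sapiens), read by FLIPR and calcium flux (on this read-out lower numbers stand for lower potency and higher numbers for higher potency (the scale is a negative logarithm)), compound 1 gives < 6.6, which is a limit of the assay and not a number.
Compound 2 `O=C(Nc1ccc2cccnc2c1)c1ccc(-c2cccc(F)c2)nc1`: compound 2 gives 8.6.
Compound 3 `O=C(Nc1ccc2cccnc2c1)c1ccc(-c2ccc(Cl)cc2)nc1`: compound 3 gives 7.8.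

Compound 3 stands lowest of the two numbers. The nearest is compound 2, and the step of a number 0.80 log units lower from compound 2 to compound 3 (beyond the scatter) lies beyond the scatter. Compound 1 contributes only a limit (the limit of < 6.6 in this assay, at which 1 of the 3 values shown sits), so the step of a number at least 1.20 log units higher from compound 1 to compound 3 (beyond the scatter) is known only as a lower bound.

Compound 4 `O=C(Nc1ccc2cccnc2c1)c1ccc(-c2ccccc2F)nc1` differs from compound 3 in one place: 2-fluorophenyl in place of 4-chlorophenyl on an aromatic carbon. Going by the values given here, two measured steps bear on this. The step of a number at least 1.20 log units higher from compound 1 to compound 3 (beyond the scatter) shows that the choice of substituent on this phenyl ring matters a great deal. The step of a number 0.80 log units lower from compound 2 to compound 3 (beyond the scatter) shows that a fluorophenyl, in that case the 3-fluorophenyl, outperformed the 4-chlorophenyl by a modest margin. Among the compounds with values here, no measured pair compares a 2-fluorophenyl with a 3-fluorophenyl, so the effect of the new position is untested. A modest rise in this assay is therefore expected, the estimated step being a number 0.30 log units higher from compound 3 to compound 4 (within the scatter). Compound 4 is expected to give about 8.1, within a range from 7.2 to 8.9.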

Compound 4, negative logarithm of the antagonist equilibrium constant: 8.7
Estimate against measurement, compound 4: 0.60 log units below; the measured number falls inside the stated range.
By their numbers in this assay, from the lowest: compound 3; then compounds 2 and 4 (each within the scatter of the next). At a limit, below all of these: compound 1.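

Replacing the 4-chlorophenyl with the 2-fluorophenyl, at the place next to the ring nitrogen, gives a number 0.90 log units higher from compound 3 to compound 4 (beyond the scatter) in this assay, so compound 3 now stands below both fluorophenyl compounds, not just one. The new result also shows that the fluorine can be placed differently on this phenyl ring with no readable change, as the step of a number 0.10 log units higher from compound 2 to compound 4 (within the scatter) lies within the scatter, and the 2-fluorophenyl and 3-fluorophenyl cannot be told apart in this assay. The comparison with the 4-cyanophenyl rests on a limit and not a number, so this step is only a bound, a number at least 2.10 log units higher from compound 1 to compound 4 (beyond the scatter): the limit of < 6.6 in this assay, at which 1 of the 4 values shown sits.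

The step to the 2-fluorophenyl changes both the halogen and its place on the ring, and the compounds shown do not separate the two, which leaves open whether a 4-fluorophenyl would match the other fluorophenyl groups or fall back towards the 4-chlorophenyl, and how a 2-chlorophenyl would compare. They also leave open how this position would respond to a group other than a halogen or nitrile on the phenyl ring, such as a methoxy group or an amine.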